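The source may report more compounds than this note shows. Statements on the series, on what has been measured and on what is new or still open speak of the compounds shown alone.

Values in a functional assay on KB cells (Homo sapiens) for antiproliferative activity, read by sulforhodamine B assay, with a stated time of 48 h; on this read-out lower numbers stand for stronger inhibition of growth and higher numbers for weaker inhibition of growth:
Compound 1 `COc1ccc(S(=O)(=O)Nc2ccccc2CCc2ccc(C(=O)Nc3ccccc3N)cc2)cc1`: 23 nM.
Compound 2 `COc1ccc(S(=O)(=O)Nc2ccccc2CCc2ccc(C(=O)NO)cc2)cc1`: > 10000 nM, a limit.
Compound 3 `COc1ccc(S(=O)(=O)Nc2ccccc2CCc2ccc(C(=O)Nc3cc(F)ccc3N)cc2)cc1`: 66 nM.

Compound 3 has the higher of the two exact numbers, and compound 1 is its nearest neighbour, with a 2.9-fold higher number from compound 1 to compound 3 (0.46 log units; beyond the scatter). That fluoro in place of hydrogen on an aromatic carbon is a modest step.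

Compound 4 `COc1ccc(S(=O)(=O)Nc2ccccc2CCc2ccc(C(=O)Nc3ccc(N)cc3)cc2)cc1` follows from compound 3 by 4-aminophenyl in place of 2-amino-5-fluorophenyl on an amide-type nitrogen. Among the measured compounds shown here, no measured step isolates this exchange. The nearest evidence is at the same nitrogen, where hydroxy in place of 2-aminophenyl gives an at least 430-fold higher number from compound 1 to compound 2 (2.63 log units; beyond the scatter) and the reverse kind of exchange gives an at least 150-fold lower number from compound 2 to compound 3 (2.18 log units; beyond the scatter). Both are large, so this nitrogen's substituent matters in compound 2 and its partners. A moderate to large rise in the number is therefore expected in this assay, with wide uncertainty.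

The expected change is a 6.1-fold higher number from compound 3 to compound 4 (0.78 log units; beyond the scatter).

Compound 4 is estimated at 400 nM, with an expected range of 40 nM to 5000 nM.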

Compound 4, concentration for 50% growth inhibition: 286 nM
Beside the measured number, compound 4's estimate is 1.4-fold (0.15 log units) above it; measured number inside the range.
By their numbers in this assay, from the lowest: compound 1; then compound 3; then compound 4. At a limit, above all of these: compound 2.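

In this assay, among the compounds shown here, 4-aminophenyl in place of 2-aminophenyl on the amide-type nitrogen gives a 12-fold higher number from compound 1 to compound 4 (1.09 log units; beyond the scatter), so the placement of the amino group on the phenyl group matters, a point the earlier compounds did not test. The exchange of 2-amino-5-fluorophenyl for 4-aminophenyl gives a 4.3-fold higher number from compound 3 to compound 4 (0.64 log units; beyond the scatter), a modest step, though it changes both the amino placement and the fluoro group. A 4-aminophenyl group still gives an at least 34-fold lower number from compound 2 to compound 4 (1.54 log units; beyond the scatter), so the 2-aminophenyl arrangement is not the only one that keeps growth inhibition well ahead of the hydroxy compound, whose value is a limit: the limit of > 10000 nM in this assay, at which 1 of the 4 values shown sits.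

As far as these compounds go, the effect of the intermediate placement remains open, as a 3-aminophenyl group on the same nitrogen would show. Also open, from the compounds shown here alone, is whether a hydroxyl group could replace the amino group on the phenyl group.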